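The source may hold more compounds than are shown below. What is called first, only, known or untested is meant among the compounds shown, and "the series" means these compounds.

Measured so far in a functional assay with Mus musculus as the target; on this read-out higher numbers stand for an effect only at larger amounts of compound and lower numbers for an effect already at smaller amounts:
compound 1, `Nc1nc(O)c2c(n1)n(C1OC(CO)[C@@H](O)[C@H]1O)c(=O)n2Cc1ccc([N+](=O)[O-])cc1`: 50 uM
compound 2, `C=CCn1c(=O)n(CCCC)c2nc(N)nc(O)c21`: 11 uM
compound 3, `CCCn1c(=O)n(C2OC(COP(=O)(O)O)[C@@H](O)[C@H]2O)c2nc(N)nc(O)c21`: 82 uM

Compound 1 stands second highest of the three numbers. Its value and that of compound 3 lie within the usual scatter, so the two cannot be told apart, while compound 2 lies beyond the scatter with a lower number. Compound 4, `CCCCCCn1c(=O)n(C2OC(CO)[C@@H](O)[C@H]2O)c2nc(N)nc(O)c21`, has not been measured. It differs from compound 1 by pentyl in place of 4-nitrophenyl on a saturated chain carbon bound to an aromatic nitrogen. Among the compounds with values here, no measured pair isolates this change, so the direction is uncertain; the lower number of compound 2, which carries no such ring group on the core, suggests a modest step toward lower numbers is expected, a 1.7-fold lower number from compound 1 to compound 4 (0.22 log units; within the scatter). Compound 4 is therefore estimated at 30 uM, between 8 uM and 120 uM.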

Compound 4, concentration for half-maximal effect: 600 uM
Beside the measured number, compound 4's estimate is 20-fold (1.30 log units) below it, and the stated range ends below it.
By their numbers in this assay, from the lowest: compound 2; then compounds 1 and 3 (each within the scatter of the next); then compound 4.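

In this assay, within the data shown here, replacing 4-nitrobenzyl with hexyl on the shared core gives a 12-fold higher number from compound 1 to compound 4 (1.08 log units; beyond the scatter) as the first change at a single place that can be read here. This position is therefore far from indifferent to what it carries, and the aromatic group with its nitro substituent goes with effect at much smaller amounts than the plain chain. Nothing measured here gives a cause for this step. Still open, on these data alone, is whether the ring or the nitro group accounts for the step. A plain benzyl group, or a benzyl group carrying an amine in place of the nitro group, would separate the two.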